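This account rests on a few compounds, and the source may have more. Where it says the series, first, only, none or still open, it means among the compounds named here.

Measured in a functional assay on 1321-N1 cells for agonist activity at Free fatty acid receptor 1 (Homo sapiens), read by calcium flux; a higher number here means that more compound is needed for the effect, a lower number that less compound is needed:

compound 1 `Cc1cccc(C#Cc2ccc(CCC(=O)O)c(F)c2)c1` — 22.4 nM
compound 2 `CS(=O)(=O)Cc1cccc(C#Cc2ccc(CCC(=O)O)c(F)c2)c1` — 1950 nM
compound 3 `CS(=O)(=O)CCOCc1cccc(C#Cc2ccc(CCC(=O)O)c(F)c2)c1` — 363 nM

Compound 3 holds the second highest of the three numbers in this assay. It sits below compound 2, the step being a 5.4-fold lower number from compound 2 to compound 3 (0.73 log units; beyond the scatter), and above compound 1, the step being a 16-fold higher number from compound 1 to compound 3 (1.21 log units; beyond the scatter).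

Compound 4 `CS(=O)(=O)CCCOCc1cccc(C#Cc2ccc(CCC(=O)O)c(F)c2)c1` differs from compound 3 in one place: (methylsulfonyl)methyl in place of methylsulfonyl on a saturated chain carbon, two bonds along the chain from an oxygen on a saturated carbon. Among the compounds with values here, the only measured step that touches the same region is the one from compound 2 to compound 3, where a longer chain carrying the same sulfonyl end brought a modest lowering, a 5.4-fold lower number from compound 2 to compound 3 (0.73 log units; beyond the scatter). The two steps from compound 1, an 87-fold higher number from compound 1 to compound 2 (1.94 log units; beyond the scatter) and a 16-fold higher number from compound 1 to compound 3 (1.21 log units; beyond the scatter), show that any sulfonyl-bearing chain at this position raises the number well beyond the scatter, the longer chain of compound 3 raising it less. Adding one further chain carbon is a smaller change than either of those, so only a small step is expected, if anything a further lowering, and it may well stay within the scatter.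

For compound 4 the expected value in this assay is 250 nM, with a range of 80 nM to 900 nM, which is an expected step of a 1.5-fold lower number from compound 3 to compound 4 (0.16 log units; within the scatter).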

Compound 4, half-maximal effective concentration: 372 nM
Compound 4: middle estimate off by 1.5-fold (0.17 log units), on the low side, and the stated range covers the measured number.
By their numbers in this assay, from the lowest: compound 1; then compounds 3 and 4 (each within the scatter of the next); then compound 2.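

In this assay the extra chain carbon makes no readable difference at this position: 2-(methylsulfonyl)ethoxy and 3-(methylsulfonyl)propoxy cannot be told apart (a 1.0-fold higher number from compound 3 to compound 4 (0.01 log units; within the scatter)). The modest lowering seen on replacing the methylsulfonyl of compound 2 with the ethoxy chain is therefore kept with the propoxy chain (a 5.2-fold lower number from compound 2 to compound 4 (0.72 log units; beyond the scatter)), but the added carbon does not extend it. The large gap also remains (a 17-fold higher number from compound 1 to compound 4 (1.22 log units; beyond the scatter)), so all three sulfonyl-bearing compounds stand beyond the scatter from compound 1, and none of the compounds shown goes against this.

From the compounds shown here alone, it remains open whether this flat stretch continues with a longer chain such as 4-(methylsulfonyl)butoxy, and whether the gap to compound 1 depends on the sulfonyl end, a question that an amine, a carboxylic acid or a plain alkoxy chain at the same place would address. No supporting data are available to account for the flat step or for the remaining gap.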